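Replacing an oxazole with an oxane on the chromanone core

A few compounds are considered here, and "the series" means these few. Any claim that something is new, unique, unknown or untested is made for them only; others in the source may bear on it.

Of the compounds shown here, three have been measured in a physicochemical assay for lipophilicity, at pH 7.4; on this read-out higher numbers stand for higher lipophilicity and lower numbers for lower lipophilicity: compound 1 `CCc1ccc(N(Cc2ccccc2)S(=O)(=O)c2ccc3c(c2)C(=O)CC(C2CCOCC2)O3)cc1`, 4.84; compound 2 `CCc1ccc(N(CC(C)C)S(=O)(=O)c2ccc3c(c2)C(=O)CC(c2c(C)noc2C)O3)cc1`, 4.42; compound 3 `CCc1ccc(N(CC(C)C)S(=O)(=O)c2ccc3c(c2)C(=O)N(C2CCOCC2)C3)cc1`, 3.64.

On these numbers compound 2 stands second highest of the three: compound 1 lies higher, beyond the scatter, and compound 3 lies lower, further away and also beyond the scatter. Compound 4 `CCc1ccc(N(CC(C)C)S(=O)(=O)c2ccc3c(c2)C(=O)CC(CC2CCOCC2)O3)cc1` has not yet been measured. It differs from compound 2 in one place: (oxan-4-yl)methyl in place of 3,5-dimethyl-1,2-oxazol-4-yl on a saturated ring carbon. Within the data shown here, no step between measured compounds isolates this change, so the account rests on expectation only. The step from compound 2 to compound 4 is expected to be a moderate rise in this assay, a number 0.38 log units higher from compound 2 to compound 4 (beyond the scatter). For compound 4 the estimate is 4.8, ranging from 4.3 to 5.3.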

Compound 4, distribution coefficient: 4.53
Estimate against measurement, compound 4: 0.27 log units above, within the range that was stated.
By their numbers in this assay, from the lowest: compound 3; then compounds 2 and 4 (each within the scatter of the next); then compound 1.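

In this assay, (oxan-4-yl)methyl in place of 3,5-dimethyl-1,2-oxazol-4-yl on a saturated ring carbon, next to the ring oxygen, gives a number 0.11 log units higher from compound 2 to compound 4 (within the scatter). Among these compounds, this is the first step to isolate a single change at this position, and it shows that an aromatic ring and a non-aromatic ring can stand here with values that cannot be told apart. Nothing at hand explains this result. Going by these compounds, whether an amine, a carboxylic acid or a longer chain on this carbon would move the number beyond the scatter in this assay remains open.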